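Benzyloxy in place of isopropoxy on the aryl at the core

The compounds below may be only part of what the source reports. "The series", "measured", "known", "first", "only" and "open" are said of these compounds alone.

Compound 2 `CC(C)Oc1ccc(C(=O)Nc2c(C(=O)O)nn(-c3ccc(Oc4ccccc4)cc3)c2-c2ccc(OC(C)C)cc2)cc1` gives 140 nM in an assay for displacement of a labelled ligand from Apoptosis regulator Bcl-2 (Homo sapiens), read by fluorescence polarization, with a stated time of 30 min (a lower number here means a stronger inhibitor, a higher number a weaker inhibitor), the second highest of the three numbers measured. Compound 1 `CCOc1ccc(-c2c(NC(=O)c3ccc(OC(C)C)cc3)c(C(=O)O)nn2-c2ccc(Oc3ccccc3)cc2)cc1` gives 28 nM, and compound 3 `CC(C)COc1ccc(C(=O)Nc2c(C(=O)O)nn(-c3ccc(Oc4ccccc4)cc3)c2-c2ccc(OC(C)C)cc2)cc1` gives 1400 nM. Compound 4 `CC(C)Oc1ccc(C(=O)Nc2c(C(=O)O)nn(-c3ccc(Oc4ccccc4)cc3)c2-c2ccc(OCc3ccccc3)cc2)cc1` differs from compound 2 by benzyl in place of isopropyl on an oxygen on an aromatic ring. Going by the values given here, two measured steps bear on this. The step of a 5.0-fold higher number from compound 1 to compound 2 (0.70 log units; beyond the scatter) occurred at the same oxygen, and the step of a 10-fold higher number from compound 2 to compound 3 (1.00 log units; beyond the scatter) occurred at the other alkoxy group; each grew an alkyl on an aromatic oxygen and weakened binding beyond the scatter. A step of similar or larger size in the weakening direction is therefore expected here, roughly a 7.1-fold higher number from compound 2 to compound 4 (0.85 log units; beyond the scatter). Compound 4 is estimated at 1000 nM, with a likely range from 300 nM to 4000 nM.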

Compound 4, inhibition constant: > 10000 nM
Compound 4: a limit, no number; the forecaster's own chance of this, stated with the estimate: 5%; middle value at least 10-fold (1.00 log units) from the limit.
By their numbers in this assay, from the lowest: compound 1; then compound 2; then compound 3. At a limit, above all of these: compound 4.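

In this assay compound 4 gives > 10000 nM, which is a limit of the assay and not a number. The steps of an at least 71-fold higher number from compound 2 to compound 4 (1.85 log units; beyond the scatter) and an at least 350-fold higher number from compound 1 to compound 4 (2.55 log units; beyond the scatter) are both large, whereas the earlier changes on alkyl groups were modest, so a benzyl on this oxygen costs far more than those compounds suggested. Across compound 1, compound 2 and compound 4, each larger group on this oxygen gives weaker binding, and none of the three goes against this.

As far as these compounds go, it remains open whether a cyclohexylmethyl on this oxygen would behave like the benzyl, which would separate the effect of size from that of an aromatic ring. A methyl there could also show whether the trend continues below the ethyl of compound 1.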